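A few compounds are considered here, and "the series" means these few. Any claim that something is new, unique, unknown or untested is made for them only; others in the source may bear on it.

Values in a functional assay on the whole organism for inhibition, with Rattus norvegicus as the target; on this read-out lower numbers stand for an effect already at smaller amounts and higher numbers for an effect only at larger amounts of compound:
- compound 1 `CC(C)c1ccc(OC(C)(Cc2ccc(Cl)cc2)c2nnn[nH]2)cc1`: 10 mg/kg
- compound 2 `CC(C)c1ccc(OC(C)(Cc2ccc(Cl)cc2)C(=O)/N=C(\N)NO)cc1`: 10 mg/kg

Compound 2 stands at 10 mg/kg, level with compound 1 on the numbers shown. Next in the series is compound 3 `CC(C)c1ccc(OC(C)(Cc2ccc(Cl)cc2)C(=N)NO)cc1`, which carries a group of 4 heavy atoms (1 carbon, 2 nitrogen, 1 oxygen; no ring) in place of a group of 7 heavy atoms (2 carbon, 3 nitrogen, 2 oxygen; no ring), on a saturated chain carbon bound to an oxygen on an aromatic ring and two saturated chain carbons. Neither the leaving nor the entering group has a ring or a net charge. No measurement covers this exact exchange. Going by the values given here, the one measured change at this place of the core shows no change at the digits printed from compound 1 to compound 2 (within the scatter), and it is the only guide. On that single step, no shift in either direction beyond the scatter is expected in this assay. The step expected is no change at the digits printed from compound 2 to compound 3 (within the scatter). With so little data, the range is kept wide. For compound 3 the estimated value is 10 mg/kg, with an expected range of 3 mg/kg to 30 mg/kg.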

Compound 3, dose for half-maximal effect: > 10 mg/kg
Compound 3: no number, only a limit; the forecaster's own chance of this, stated with the estimate: 15%; the middle value sits exactly at the limit.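

In this assay compound 3 gives > 10 mg/kg, which is a limit of the assay and not a number. The exchange at this saturated chain carbon gives a number no lower from compound 2 to compound 3 (the limit leaves the size open), and the same place also gives a number no lower from compound 1 to compound 3 (the limit leaves the size open). Going by these compounds alone, neither step can be read in size, so the level reading seen for the first exchange at this saturated chain carbon does not carry over to the group of 4 heavy atoms as a measured equivalence. What this change shows is therefore bounded by one reading: the limit of > 10 mg/kg in this assay, at which 1 of the 3 values shown sits.

On these data alone, how far compound 3 actually lies from compound 1 and compound 2 stays open, as no number exists for it. Also open, as far as these compounds go, is whether a carboxylic acid or a nitrile on this same carbon would give a readable value in this assay, with the rest of the shared core unchanged.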